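The source may hold more compounds than are shown below. What is called first, only, known or untested is meant among the compounds shown, and "the series" means these compounds.

Compound 1 `O=C1C=C[C@]2(O)CCO[C@@H]2C1` gives 2.8 ug/mL in a functional assay on HeLa S3 cells (Homo sapiens) for cytotoxicity; a higher number here means a weaker inhibitor, a lower number a stronger inhibitor. Compound 2 `CC(=O)O[C@]12C=CC(=O)C[C@H]1OCC2` gives 4.1 ug/mL in this assay; the step of a 1.5-fold higher number from compound 1 to compound 2 (0.17 log units; within the scatter) lies within the scatter, so compound 2 sits alongside compound 1 rather than apart from it. Compound 3 `O=C1C=C[C@]2(OC(=O)c3ccccc3)CCO[C@@H]2C1` carries phenyl in place of methyl on a carbonyl carbon. Among the measured compounds shown here, the single measured step, a 1.5-fold higher number from compound 1 to compound 2 (0.17 log units; within the scatter), concerns a different change and shows only that acetyl in place of hydrogen left the number within the scatter; no measured step speaks to phenyl in place of methyl on the carbonyl carbon. The expected step of a 1.1-fold higher number from compound 2 to compound 3 (0.04 log units; within the scatter) is therefore none beyond the scatter. Compound 3 is estimated at 4.5 ug/mL, in the range 2 ug/mL to 10 ug/mL.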

Compound 3, half-maximal inhibitory concentration: 1.6 ug/mL
Compound 3: middle estimate off by 2.8-fold (0.45 log units), on the high side; the measured number lies below the stated range.
By their numbers in this assay, from the lowest: compounds 3, 1 and 2 (each within the scatter of the next, the first and the last beyond it).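

In this assay, among the compounds shown here, the change of phenyl in place of methyl on a carbonyl carbon gives a 2.6-fold lower number from compound 2 to compound 3 (0.41 log units; beyond the scatter), the only step beyond the scatter. The earlier step, a 1.5-fold higher number from compound 1 to compound 2 (0.17 log units; within the scatter), stayed within the scatter, so this position now shows a response to the group on the carbonyl carbon that the acetyl alone did not reveal. Nothing available explains this step.

Going by these compounds, whether a longer chain on that carbonyl carbon would give a similar number remains open. So does the effect of an amine or a carboxylic acid on the phenyl ring.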